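This account rests on a few compounds, and the source may have more. Where it says the series, first, only, none or still open, it means among the compounds named here.

Of the compounds shown here, three have so far been measured in a functional assay on MCF7 cells (Homo sapiens) for antiproliferative activity; a higher number here means a weaker inhibitor, a lower number a stronger inhibitor. Among the compounds with values here, compound 1 `CC(=O)Oc1ccc(C(=O)Nc2cc3ccc(OCC4CCCN(C)C4)c(C)c3oc2=O)cc1CC=C(C)C` gives 1650 nM, and compound 2 `CC(=O)Oc1ccc(C(=O)Nc2cc3ccc(OCC4CCN(C)C4)c(C)c3oc2=O)cc1CC=C(C)C` gives 1880 nM; the step between them, a 1.1-fold higher number from compound 1 to compound 2 (0.06 log units; within the scatter), is the only single-site change among the measured compounds. Compound 3 `CC(C)=CCc1cc(C(=O)Nc2cc3ccc(OCCCNCC(C)C)c(C)c3oc2=O)ccc1O` gives 1320 nM, the lowest of the three numbers, though its gaps to compound 1 and to compound 2 both fall within the scatter, so no order among the three can be drawn. Compound 4 `CC(C)=CCc1cc(C(=O)Nc2cc3ccc(OCCCNC4CCCCC4)c(C)c3oc2=O)ccc1O` has not yet been measured. It differs from compound 3 by a single change: cyclohexyl in place of isobutyl on an amine nitrogen. Within the data shown here, no measured step touches the amine nitrogen; the one step known, a 1.1-fold higher number from compound 1 to compound 2 (0.06 log units; within the scatter), concerns a ring on a saturated chain carbon bound to an oxygen on an aromatic ring and stayed within the scatter, so it bears only loosely on the present change. Relative to compound 3, compound 4 is expected to show a step of a 1.0-fold lower number from compound 3 to compound 4 (0.01 log units; within the scatter), not expected to exceed the scatter. Compound 4 is therefore estimated at 1300 nM, with a range from 500 nM to 3500 nM.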

Compound 4, half-maximal inhibitory concentration: 1070 nM
Compound 4: middle estimate off by 1.2-fold (0.08 log units), on the high side; measured number inside the range.
By their numbers in this assay, from the lowest: compounds 4, 3, 1 and 2 (each within the scatter of the next).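

Within the data shown here, this is the first measured step at the amine nitrogen: in this assay, cyclohexyl in place of isobutyl gives a 1.2-fold lower number from compound 3 to compound 4 (0.09 log units; within the scatter). Compound 3 and compound 4 therefore cannot be told apart in this read-out, so a six-membered non-aromatic ring of carbon only can stand on this nitrogen in place of the open-chain isobutyl without a step beyond the scatter.

From the compounds shown here alone, what a phenyl ring, a small methyl group or a chain ending in a carboxylic acid would do on this nitrogen remains open. Among these compounds, with only this one pair at the position, it is also open whether any group placed here can move the number beyond the scatter.

Nothing available explains why these two groups cannot be told apart here.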